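Swapping pyrrolidin-1-yl for a hydroxymethyl triazole

The source may report more compounds than this note shows. Statements on the series, on what has been measured and on what is new or still open speak of the compounds shown alone.

Compound 1 `CCN(CC)C/C1=C/C[C@](C)(CCC=C(C)C)/C=C/[C@@H](OC(=O)C=C(C)C)[C@](C)(O)/C=C/C1=O` gives 140 nM
Compound 2 `CC(C)=CCC[C@]1(C)/C=C/[C@@H](OC(=O)C=C(C)C)[C@](C)(O)/C=C/C(=O)/C(CN2CCCC2)=C\C1` gives 160 nM
Compound 3 `CC(C)=CCC[C@]1(C)/C=C/[C@@H](OC(=O)C=C(C)C)[C@](C)(O)/C=C/C(=O)/C(Cn2cc(CO)nn2)=C\C1` has not yet been measured

Within the data shown here, in a functional assay on HL-60 cells (Homo sapiens) for antiproliferative activity, read by MTT assay, with a stated time of 48 h (on this read-out lower numbers stand for stronger inhibition and higher numbers for weaker inhibition), compound 2 gives 160 nM and stands within the scatter of compound 1, the only other measured compound. Compound 3 carries 4-(hydroxymethyl)-1H-1,2,3-triazol-1-yl in place of pyrrolidin-1-yl on a saturated chain carbon bound to a double-bonded ring carbon. Among the measured compounds shown here, one measured step bears on this place (a 1.1-fold higher number from compound 1 to compound 2 (0.06 log units; within the scatter)), where pyrrolidin-1-yl replaced diethylamino. For the measured compounds named here, it stays within the scatter, but it is only a weak guide, since no measured compound carries a triazole or a hydroxymethyl group. The new group differs far more from pyrrolidin-1-yl than pyrrolidin-1-yl does from diethylamino, so a real step is expected in this assay, most likely towards a higher number, though its size is uncertain. The expected step is a 2.8-fold higher number from compound 2 to compound 3 (0.45 log units; beyond the scatter) (an estimate). The estimate for compound 3 is 450 nM (expected range 130 nM to 1800 nM).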

Compound 3, half-maximal inhibitory concentration: 3200 nM
The estimate for compound 3 lay 7.1-fold (0.85 log units) below the measured number; measured number above the stated range.
By their numbers in this assay, from the lowest: compounds 1 and 2 (each within the scatter of the next); then compound 3.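

In this assay, the position on a saturated chain carbon bound to a double-bonded ring carbon proved far from indifferent to what it carries. Diethylamino and pyrrolidin-1-yl had stood within the scatter of each other, but 4-(hydroxymethyl)-1H-1,2,3-triazol-1-yl in place of pyrrolidin-1-yl gave a large step (a 20-fold higher number from compound 2 to compound 3 (1.30 log units; beyond the scatter)), and the same group in place of diethylamino gave another (a 23-fold higher number from compound 1 to compound 3 (1.36 log units; beyond the scatter)). The shared core is unchanged in these pairs, so the rise in the number belongs to this one replacement, although nothing available explains why it occurs.

The compounds shown leave open which part of the entering group goes with the rise, since the aromatic triazole ring and its hydroxymethyl group arrive together, and a triazole bearing a plain methyl group in place of hydroxymethyl would begin to separate the two. They also leave open how widely the position accepts amines, as only diethylamino and pyrrolidin-1-yl appear here, and a piperidin-1-yl or morpholin-4-yl group could stay with compound 1 and compound 2 or move towards compound 3.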